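Changing the aryl group on the triazole of a bicyclic lactam

The source may hold more compounds than are shown below. What is called first, only, known or untested is meant among the compounds shown, and "the series" means these compounds.

Compound 1 `CC1(C)[C@H]2CC[C@]1(C)N(Cc1cn(-c3cccc(F)c3)nn1)C(=O)C2` is the weakest of three close analogues in a functional assay on OVCAR-3 cells (Homo sapiens) for inhibition, read by MTT assay, with a stated time of 24 h (a lower number here means a stronger inhibitor, a higher number a weaker inhibitor), where compound 1 gives 430 nM. Its two neighbours carry a different aryl group on the triazole nitrogen. Compound 2 `CC1(C)[C@H]2CC[C@]1(C)N(Cc1cn(-c3ccccc3Cl)nn1)C(=O)C2` gives 40 nM, and compound 3 `CC1(C)[C@H]2CC[C@]1(C)N(Cc1cn(-c3ccccc3)nn1)C(=O)C2` gives 50 nM. The two changes away from compound 1 are both large: an 11-fold lower number from compound 1 to compound 2 (1.03 log units; beyond the scatter) and an 8.6-fold lower number from compound 1 to compound 3 (0.93 log units; beyond the scatter). Between the two neighbours themselves there is a 1.3-fold higher number from compound 2 to compound 3 (0.10 log units; within the scatter), so a chloro on the phenyl ring and a bare phenyl ring give the same result.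

Compound 4 `CC1(C)[C@H]2CC[C@]1(C)N(Cc1cn(-c3ccc(Br)cc3)nn1)C(=O)C2` differs from compound 1 in one place: 4-bromophenyl in place of 3-fluorophenyl on an aromatic nitrogen. Within the data shown here, the steps that bear on this change are those from compound 1 to compound 2 and from compound 1 to compound 3, both of which lower the number once the 3-fluorophenyl is gone. A 4-bromophenyl has not been measured, but on these two steps compound 4 is expected to give a lower number than compound 1, roughly a 6.1-fold lower number from compound 1 to compound 4 (0.79 log units; beyond the scatter). Compound 4 is therefore estimated at 70 nM, with a range from 25 nM to 200 nM.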

Compound 4, half-maximal inhibitory concentration: 140 nM
Estimate against measurement, compound 4: 2.0-fold (0.30 log units) below, and the stated range covers the measured number.
By their numbers in this assay, from the lowest: compounds 2 and 3 (each within the scatter of the next); then compound 4; then compound 1.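

In this assay, among these compounds, the 4-bromophenyl lands part of the way along the range the earlier compounds opened: replacing the 3-fluorophenyl gives a 3.1-fold lower number from compound 1 to compound 4 (0.49 log units; beyond the scatter), yet adding the bromo to the bare phenyl gives a 2.8-fold higher number from compound 3 to compound 4 (0.45 log units; beyond the scatter). The earlier compounds shown here left open whether a halogen on this phenyl ring matters at all, since the 2-chlorophenyl and the bare phenyl could not be told apart, but here the 4-bromophenyl does separate from both, with a 3.5-fold higher number from compound 2 to compound 4 (0.54 log units; beyond the scatter). Among these four compounds, then, a halogen on the ring does not have one outcome, and nothing in the data shown explains why these aryl groups differ.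

The compounds shown change the halogen and its place on the ring together, so a 4-fluorophenyl or a 3-bromophenyl would be needed to tell these two changes apart. Also open, as far as these compounds go, is how the number would respond to a phenyl ring bearing an amine or a carboxylic acid, or to a pyridyl ring or an alkyl chain on the aromatic nitrogen in place of the phenyl ring.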